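This account rests on a few compounds, and the source may have more. Where it says the series, first, only, none or still open, it means among the compounds named here.

Measured so far:
- compound 1, `O=c1[nH]c(=O)n([C@H]2C[C@H](O)[C@@H](CO)O2)cc1-c1cn(CCC(F)(F)C(F)(F)C(F)(F)C(F)(F)F)nn1`: 116 uM
- compound 2, `O=c1[nH]c(=O)n([C@H]2C[C@H](O)[C@@H](CO)O2)cc1-c1cn(CCC(F)(F)C(F)(F)C(F)(F)C(F)(F)C(F)(F)C(F)(F)F)nn1`: 99.3 uM

Both compounds share one core and differ only in the length of the fluorinated chain on the triazole side arm. In a functional assay on ACHN cells (Homo sapiens) for antiproliferative activity, read by sulforhodamine B assay (a higher number here means a weaker inhibitor of growth, a lower number a stronger inhibitor of growth), compound 1 gives 116 uM, and compound 2 gives 99.3 uM. Among the compounds with values here, the two numbers sit within the scatter of each other, so neither can be called the stronger inhibitor; the one computed step, a 1.2-fold lower number from compound 1 to compound 2 (0.07 log units; within the scatter), shows that adding 1,1,2,2,2-pentafluoroethyl in place of fluoro on a saturated chain carbon bound to two fluorine atoms and a saturated chain carbon left growth inhibition essentially unchanged.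

Compound 3, `O=c1[nH]c(=O)n([C@H]2C[C@H](O)[C@@H](CO)O2)cc1-c1cn(CCC(F)(F)C(F)(F)F)nn1`, has not yet been measured. It differs from compound 1 by fluoro in place of 1,1,2,2,2-pentafluoroethyl on a saturated chain carbon bound to two fluorine atoms and a saturated chain carbon, that is, the chain is cut back rather than extended. Within the data shown here, the only comparable step, a 1.2-fold lower number from compound 1 to compound 2 (0.07 log units; within the scatter), points to the chain length having little effect in either direction, so no step beyond the scatter is expected for compound 3: a 1.0-fold higher number from compound 1 to compound 3 (0.01 log units; within the scatter). Compound 3 is therefore estimated at 120 uM, within 60 uM to 240 uM.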

Compound 3, concentration for growth inhibition (reported as GI): 96.1 uM
Beside the measured number, compound 3's estimate is 1.2-fold (0.10 log units) above it; the range from low to high includes it.
By their numbers in this assay, from the lowest: compounds 3, 2 and 1 (each within the scatter of the next).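

Cutting the side arm back, with fluoro in place of 1,1,2,2,2-pentafluoroethyl on a saturated chain carbon bound to two fluorine atoms and a saturated chain carbon, gives a 1.2-fold lower number from compound 1 to compound 3 (0.08 log units; within the scatter) in this assay. The earlier pair showed only what happens when this fluorinated chain is extended; this result adds the opposite change, so the chain has now been both lengthened and shortened from compound 1 without a step beyond the scatter, and the three chains shown cannot be told apart by this growth read-out. No outside measurement is available here to explain this flat result, such as one showing how these compounds behave in or around the cells.

The compounds shown leave open whether this flatness extends to other kinds of chain, since all three carry fluorinated chains and a much longer chain or a plain hydrocarbon chain without fluorine could behave differently. They also leave open whether an amine or a carboxylic acid in place of fluoro on that saturated chain carbon would move the number beyond the scatter.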